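Rat Liver Microsome Stability Across a Sulfone Series

The source may report more compounds than this note shows. Statements on the series, on what has been measured and on what is new or still open speak of the compounds shown alone.

Compound 2 `CCCCc1nc(=O)c(S(=O)(=O)c2ccc(-n3ccccc3=O)cc2)c(O)n1-c1c(OC)cccc1OC` was tested in an ADME assay on microsomes from liver (Rattus norvegicus) for metabolic stability, using NADPH, with a stated time of 10 min (a lower number here means that less of the compound is left, a higher number that more of the compound is left), and gave 83%. Compound 1 `CCCCc1nc(=O)c(S(=O)(=O)c2ccc(-c3ccc(F)nc3)cc2)c(O)n1-c1c(OC)cccc1OC` gave 2% in this assay. Among the measured compounds shown here, of the two measured compounds, compound 2 stands highest, and its only neighbour is compound 1, separated by the step of a number 81 percentage points higher from compound 1 to compound 2 (beyond the scatter). Compound 3 `CCCCc1nc(=O)c(S(=O)(=O)c2ccc(C)cc2)c(O)n1-c1c(OC)cccc1OC` has not yet been measured. It differs from compound 2 by one carbon atom in place of a group of 7 heavy atoms (5 carbon, 1 nitrogen, 1 oxygen; one six-membered aromatic ring with 1 hetero atom), on an aromatic carbon, an exchange on an aromatic carbon. For the measured compounds named here, the one measured step that touches this part of the molecule is a number 81 percentage points higher from compound 1 to compound 2 (beyond the scatter), a large gain when the group on that aromatic carbon was exchanged. The methyl that enters in compound 3 is not the group that accompanied the high value of compound 2, and compound 1, with another group on that aromatic carbon, gave 2%. For compound 3 a large fall is therefore expected, a number 58 percentage points lower from compound 2 to compound 3 (beyond the scatter). The estimated value of compound 3 in this assay is 25%, with a range from 3% to 70%.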

Compound 3, percent of the compound remaining: 74%
The estimate for compound 3 lay 49 percentage points below the measured number, and the stated range ends below it.
By their numbers in this assay, from the lowest: compound 1; then compounds 3 and 2 (each within the scatter of the next).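

In this assay, replacing the ring group of compound 2 with a single methyl gives a number 9 percentage points lower from compound 2 to compound 3 (within the scatter), so at this position, para to a large group, the two groups cannot be told apart and the larger group is not required for a high number. Among the compounds shown here, exchanging 6-fluoropyridin-3-yl for methyl gives a number 72 percentage points higher from compound 1 to compound 3 (beyond the scatter), which sets compound 1 apart as the only low compound of the three, with two quite different groups giving high numbers. Nothing available here explains these numbers.

The compounds shown leave open whether the low number of compound 1 goes with the pyridine ring of its group or with the fluorine on that ring, a question that an unsubstituted pyridin-3-yl at this position could address. On these data alone, how an amine, a carboxylic acid or a longer alkyl chain on the same carbon would behave also remains unknown.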